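Aryl piperazine variation on the shared core: chloro to methoxy

The source may report more compounds than this note shows. Statements on the series, on what has been measured and on what is new or still open speak of the compounds shown alone.

Measured compounds and their cytotoxicity numbers:
- Compound 1 `COc1cc(Cc2cnc(/N=C3\C(=O)N(CN(Cc4ccccc4)Cc4ccccc4)c4ccc(Cl)cc43)nc2N)cc(OC)c1OC`, 37.1 ug/mL
- Compound 2 `COc1cc(Cc2cnc(/N=C3\C(=O)N(CN4CCN(C)CC4)c4ccc(Cl)cc43)nc2N)cc(OC)c1OC`, 88 ug/mL
- Compound 3 `COc1cc(Cc2cnc(/N=C3\C(=O)N(CN4CCN(c5cccc(Cl)c5)CC4)c4ccc(Cl)cc43)nc2N)cc(OC)c1OC`, 34.4 ug/mL

All three were read in an ADME assay on CCRF-CEM cells (Homo sapiens) for cytotoxicity, read by MTT assay, with a stated time of 5 days; a lower number here means that less compound is tolerated, a higher number that more compound is tolerated. Compound 3 gives the lowest of the three numbers. For the measured compounds named here, its gap to compound 1 lies within the scatter, so the two cannot be ordered; only compound 2 stands apart, by a 2.6-fold lower number from compound 2 to compound 3 (0.41 log units; beyond the scatter), the one step in this set that is beyond the scatter.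

Compound 4 `COc1cccc(N2CCN(CN3C(=O)/C(=N\c4ncc(Cc5cc(OC)c(OC)c(OC)c5)c(N)n4)c4cc(Cl)ccc43)CC2)c1` keeps the core and the piperazine of compound 3 and changes the aryl substituent: methoxy in place of chloro on an aromatic carbon. Going by the values given here, no measured step touches a substituent on that aryl ring. The step from compound 2 to compound 3 concerns what sits on the amine nitrogen, not what sits on the ring, so it bears on this change only indirectly: it shows that the aryl-bearing compound 3 sits at the low end of the set, and compound 4 keeps that aryl ring. Among the compounds with values here, with no direct precedent, the expected step of a 1.0-fold higher number from compound 3 to compound 4 (0.02 log units; within the scatter) in this assay is none beyond the scatter. Compound 4 is therefore expected at 36 ug/mL, within 18 ug/mL to 72 ug/mL.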

Compound 4, half-maximal cytotoxic concentration: 23.3 ug/mL
The estimate for compound 4 lay 1.5-fold (0.19 log units) above the measured number, within the range that was stated.
By their numbers in this assay, from the lowest: compounds 4, 3 and 1 (each within the scatter of the next); then compound 2.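

For the compounds shown here, this is the first measured change on the aryl ring itself, and in this assay the move from 3-chlorophenyl to 3-methoxyphenyl gives a 1.5-fold lower number from compound 3 to compound 4 (0.17 log units; within the scatter) and so does not separate the two compounds at this place on the ring. The distance from the methyl-bearing compound 2 stands with either substituent, with a 2.6-fold lower number from compound 2 to compound 3 (0.41 log units; beyond the scatter) for the chloro compound and a 3.8-fold lower number from compound 2 to compound 4 (0.58 log units; beyond the scatter) for the methoxy compound, so exchanging chloro for methoxy leaves compound 4 apart from compound 2 just as compound 3 is. No measurement in hand bears on why the numbers fall as they do.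

Only two substituents at one place on the aryl ring are shown, so it stays open whether an amine, a carboxylic acid or a nitrile there would move the number beyond the scatter, and whether chloro or methoxy on another carbon of that ring would do so. Also open, from the compounds shown here alone, is how a longer chain between the piperazine nitrogen and the aryl ring would read in this assay against compound 3 and compound 4.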